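Extending the methyl of compound 3 into a cyanoalkyl chain

A few compounds are considered here, and "the series" means these few. Any claim that something is new, unique, unknown or untested is made for them only; others in the source may bear on it.

Measured so far:
Compound 1, `OCc1ccnc(-c2nn(Cc3ccccc3F)c3ncccc23)n1` — in a functional assay (aorta) with Oryctolagus cuniculus as the target (a lower number here means a stronger inhibitor, a higher number a weaker inhibitor), compound 1 gives 1300 nM.
Compound 2, `Fc1ccccc1Cn1nc(-c2cc[nH]n2)c2cccnc21` — in this assay compound 2 gives 1800 nM.
Compound 3, `Cc1cnc(-c2nn(Cc3ccccc3F)c3ncccc23)nc1N` — in this assay compound 3 gives 675000 nM.

Compound 3 stands at the highest number of the three, far from the other two: a 520-fold higher number from compound 1 to compound 3 (2.72 log units; beyond the scatter) and a 380-fold higher number from compound 2 to compound 3 (2.57 log units; beyond the scatter). Between compounds 1 and 2 the step is small, a 1.4-fold higher number from compound 1 to compound 2 (0.14 log units; within the scatter), so the shared core tolerates either of those two aromatic groups, while the 4-amino-5-methylpyrimidin-2-yl of compound 3 sits apart.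

Compound 4, `CC(C#N)CCCCCc1cnc(-c2nn(Cc3ccccc3F)c3ncccc23)nc1N`, keeps that weak aromatic group and changes only the chain: 5-cyanohexyl in place of hydrogen on a saturated chain carbon bound to an aromatic carbon. Among the measured compounds shown here, no measured step touches this place; all three recorded steps exchange the aromatic group on the core, and none alters a saturated chain carbon. For the measured compounds named here, there is thus nothing in the set that bears directly on the change from compound 3 to compound 4, and the only anchor is the value of compound 3 itself.

Going by the values given here, with no comparable step on record, compound 4 is expected to stay near compound 3, the step of a 1.4-fold lower number from compound 3 to compound 4 (0.13 log units; within the scatter) being estimated as none beyond the scatter, though with wide uncertainty. For compound 4 the estimate in this assay is 500000 nM, within a range of 100000 nM to 2500000 nM.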

Compound 4, half-maximal inhibitory concentration: 1290000 nM
Estimate against measurement, compound 4: 2.6-fold (0.41 log units) below; the measured number falls inside the stated range.
By their numbers in this assay, from the lowest: compounds 1 and 2 (each within the scatter of the next); then compounds 3 and 4 (each within the scatter of the next).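

In this assay, among the compounds shown here, this is the first step at the chain rather than at the aromatic group on the core: going from methyl to 6-cyanoheptyl gives a 1.9-fold higher number from compound 3 to compound 4 (0.28 log units; within the scatter). A long chain ending in a nitrile is therefore accommodated at this place on the 4-amino-5-methylpyrimidin-2-yl group without a step beyond the scatter, although the result comes from a single pair and both of its compounds have very high numbers. Nothing available accounts for why so large an addition gives so small a step.

Whether the same chain would be accommodated on the stronger compounds remains open, since the 4-(hydroxymethyl)pyrimidin-2-yl and 1H-pyrazol-3-yl groups of compound 1 and compound 2 carry no such chain in the compounds shown. Also open, on these data alone, is whether an amine or a carboxylic acid at the chain end in place of the nitrile, or a shorter chain such as ethyl, would give a step beyond the scatter from compound 3.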